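The source may report more compounds than this note shows. Statements on the series, on what has been measured and on what is new or still open speak of the compounds shown alone.

Compound 1 `Nc1ncnc2c1c(-c1ccccc1)cn2-c1ccc(S(=O)(=O)Nc2nccs2)cc1` and compound 2 `Nc1ncnc2c1c(-c1ccccc1)cn2-c1ccc(S(=O)(=O)Nc2ccccn2)cc1` share one core; compound 3 `N#Cc1c(-c2ccccc2)cn(-c2ccc(S(=O)(=O)Nc3nccs3)cc2)c1NC(N)=O` and compound 4 `N#Cc1c(-c2ccccc2)cn(-c2ccc(S(=O)(=O)Nc3ccccn3)cc2)c1NC(N)=O` share another, and the difference between the two cores is not broken down here. In a functional assay on MCF7 cells (Homo sapiens) for inhibition, read by sulforhodamine B assay, with a stated time of 24 h (on this read-out lower numbers stand for stronger inhibition and higher numbers for weaker inhibition), compound 1 gives 6450 nM, compound 2 gives 6340 nM and compound 3 gives 8050 nM. The change from compound 1 to compound 2, (pyridin-2-yl in place of 1,3-thiazol-2-yl on a sulfonamide nitrogen), gave a 1.0-fold lower number from compound 1 to compound 2 (0.01 log units; within the scatter). The same kind of change is made from compound 3 to compound 4, (pyridin-2-yl in place of 1,3-thiazol-2-yl on a sulfonamide nitrogen), at a place described in the same words. Since the earlier step is within the scatter, the step from compound 3 to compound 4 in this assay is expected to be flat as well, about a 1.0-fold lower number from compound 3 to compound 4 (0.00 log units; within the scatter), resting on compound 1 at 6450 nM lying level with compound 2 at 6340 nM. Compound 4 is therefore estimated at 8000 nM, with a range of 4000 nM to 16000 nM.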

Compound 4, half-maximal inhibitory concentration: 7340 nM
For compound 4 the middle estimate is 1.1-fold (0.04 log units) above the measured one; the range from low to high includes it.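

In this assay, replacing 1,3-thiazol-2-yl with pyridin-2-yl on a sulfonamide nitrogen is also flat on the second core, giving a 1.1-fold lower number from compound 3 to compound 4 (0.04 log units; within the scatter). The two steps agree: the same change on two cores in this assay, a 1.0-fold lower number (0.01 log units; within the scatter) from compound 1 to compound 2 and a 1.1-fold lower number (0.04 log units; within the scatter) from compound 3 to compound 4, 1.1-fold (0.03 log units) apart, within the scatter of two such steps. This shows the change leaving the number level on both cores in this one assay, but two flat steps do not show that a change with a real effect would carry from one core to the other, and they say nothing about other cores or other read-outs.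

From the compounds shown here alone, it remains open whether any group on the sulfonamide nitrogen moves the number beyond the scatter, for instance a methyl, an unsubstituted phenyl or a pyrimidin-2-yl. Also open, going by these compounds, is how these two cores respond to a carboxylic acid or an amine on the phenyl ring.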